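This account rests on a few compounds, and the source may have more. Where it says the series, first, only, none or still open, it means among the compounds named here.

Compound 1 `CCc1c(Cc2c(Cl)cccc2Cl)nc(SCC(=O)c2ccccc2)[nH]c1=O`: > 52000 nM
Compound 2 `CCc1c(Cc2c(F)cccc2Cl)nc(SCC(=O)c2ccccc2)[nH]c1=O`: > 12000 nM
Compound 3 `CCc1c(Cc2c(F)cccc2Cl)nc(SCC(=O)c2ccc(F)cc2)[nH]c1=O`: > 57000 nM

All three compounds were tested in an ADME assay on MT4 cells (Homo sapiens) for cytotoxicity, read by MTT assay (a lower number here means that less compound is tolerated, a higher number that more compound is tolerated), and each returned only a limit, not a number. Compound 2 stands at > 12000 nM, which is a limit, so the account starts without a firm value.

The step in question leads to compound 4 `CCc1c(Cc2c(F)cccc2F)nc(SCC(=O)c2ccccc2)[nH]c1=O`, and the structural change is fluoro in place of chloro on an aromatic carbon. In other words, 2-chloro-6-fluorobenzyl becomes 2,6-difluorobenzyl.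

Within the data shown here, two measured steps bear on this. The closest is a step that the two limits leave unreadable from compound 1 to compound 2, which is the same exchange of fluoro in place of chloro on an aromatic carbon. The other is a step that the two limits leave unreadable from compound 2 to compound 3, a different change, with fluoro in place of hydrogen on an aromatic carbon. Neither gives a size, so the data offer no measured effect to carry over to this assay. None of the three compounds has a number showing poor tolerance, and compound 4 is expected to be tolerated in a similar way, probably again with only a limit reported.

The estimated step is a step that the limit leaves unreadable from compound 2 to compound 4, and its size is uncertain. For compound 4 the expected value is 40000 nM, with an estimated range of 12000 nM to 130000 nM.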

Compound 4, half-maximal cytotoxic concentration: 56000 nM
For compound 4 the middle estimate is 1.4-fold (0.15 log units) below the measured one, within the range that was stated.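

In this assay, the steps to compound 4 from compound 1 and from compound 2 cannot be read: compound 1 and compound 2 carry only limits, so no size follows. The compounds shown leave open how large a change, if any, fluoro in place of chloro on an aromatic carbon brings in this assay.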